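Terminal amine variation at the chain end

The compounds below may be only part of what the source reports. "The series", "measured", "known", "first", "only" and "open" are said of these compounds alone.

Compound 3 `CCN1CCN(CCCOc2cc3ncnc(Nc4ccc(C#N)cc4)c3cc2OC)CC1` gives the lowest of the two numbers in a functional assay on HepG2 cells (Homo sapiens) for antiproliferative activity, read by MTT assay, with a stated time of 72 h (a lower number here means a stronger inhibitor, a higher number a weaker inhibitor), at 9580 nM. Compound 1 `CCN(CC)CCCOc1cc2ncnc(Nc3ccc(C#N)cc3)c2cc1OC` gives 59400 nM in this assay. Compound 2 `COc1cc2c(Nc3ccc(C#N)cc3)ncnc2cc1OCCCN1CCCCC1CCO` reaches only a limit of the assay, > 100000 nM (the limit of > 100000 nM in this assay, at which 1 of the 3 values shown sits). All measured steps exchange the amine on the saturated chain, three bonds along the chain from an oxygen on an aromatic ring: a 6.2-fold lower number from compound 1 to compound 3 (0.79 log units; beyond the scatter), an at least 10-fold lower number from compound 2 to compound 3 (1.01 log units; beyond the scatter) and an at least 1.6-fold higher number from compound 1 to compound 2 (0.22 log units; that floor lies within the scatter).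

Compound 4 `COc1cc2c(Nc3ccc(C#N)cc3)ncnc2cc1OCCCN1CCN(c2ccncc2)CC1` differs from compound 3 by pyridin-4-yl in place of ethyl on an amine nitrogen in a ring. Going by the values given here, no measured step alters a substituent on the piperazine nitrogen itself, so the direction cannot be read from the data; the amine-end steps only show that changes in this region moved the numbers by modest to large amounts. The step to compound 4 is therefore expected to be of that order, taken as a 2.1-fold higher number from compound 3 to compound 4 (0.32 log units; beyond the scatter) toward a higher number, with wide uncertainty. Compound 4 is estimated at 20000 nM, within 5000 nM to 80000 nM.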

Compound 4, half-maximal inhibitory concentration: 12600 nM
Compound 4: middle estimate off by 1.6-fold (0.20 log units), on the high side; low and high end bracket the measured number.
By their numbers in this assay, from the lowest: compounds 3 and 4 (each within the scatter of the next); then compound 1. At a limit, above all of these: compound 2.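

In this assay, going by these compounds alone, this is the first measured change on the amine nitrogen of the piperazine, and a whole six-membered aromatic ring in place of ethyl gives a 1.3-fold higher number from compound 3 to compound 4 (0.12 log units; within the scatter) with no separation of the two compounds. The gain over the diethylamino compound therefore holds with either substituent on that nitrogen, with a 4.7-fold lower number from compound 1 to compound 4 (0.67 log units; beyond the scatter) as the second such step. The step of an at least 7.9-fold lower number from compound 2 to compound 4 (0.89 log units; beyond the scatter) is a floor only, and its starting value is a limit: the limit of > 100000 nM in this assay, at which 1 of the 4 values shown sits.

From the compounds shown here alone, whether this tolerance extends beyond pyridin-4-yl remains open, for example to phenyl, to a pyridin-2-yl isomer or to a free amine hydrogen on that nitrogen. Also open, going by these compounds, is how morpholine at the chain end or a shorter chain would compare.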